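Butylsulfonyl in place of isopropylcarbonyl on compound 3

This account rests on a few compounds, and the source may have more. Where it says the series, first, only, none or still open, it means among the compounds named here.

Of the compounds shown here, three have numbers so far in a physicochemical assay for solubility, in phosphate buffer, at pH 7.4; a lower number here means a less soluble compound, a higher number a more soluble compound. Compound 1 (`CCC(C)C(=O)N1CCC(NC(=O)Nc2ccc(C(C)(C)C)cc2)CC1`) gives 0.02 ug/mL, compound 2 (`CCC(C)C(=O)N1CCC(NC(=O)N[C@H]2CC[C@H](CC)CC2)CC1`) gives 39.5 ug/mL, and compound 3 (`CC(C)C(=O)N1CCC(NC(=O)Nc2ccc(OC(F)(F)F)cc2)CC1`) gives 27 ug/mL. Compound 3 therefore stands within the scatter of compound 2, while compound 1 lies lower than compound 3, well beyond the scatter.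

Compound 4 (`CCCCS(=O)(=O)N1CCC(NC(=O)Nc2ccc(OC(F)(F)F)cc2)CC1`) has not yet been measured. It carries butylsulfonyl in place of isopropylcarbonyl on an amine nitrogen in a ring. Among the compounds with values here, no two measured compounds differ in one place only, so the series offers no direct precedent for this change. The wide gap between compound 1 and compound 3 shows how far values can spread in this series, but it cannot be assigned to any single group.

The expectation therefore rests on the structural change alone and is uncertain. A moderate fall in this assay is expected, beyond the scatter but far smaller than that gap, with the estimated step of a 3.4-fold lower number from compound 3 to compound 4 (0.53 log units; beyond the scatter). Compound 4 is estimated at 8 ug/mL, with an expected range of 1.5 ug/mL to 30 ug/mL.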

Compound 4, solubility: 0.6 ug/mL
Compound 4: middle estimate off by 13-fold (1.12 log units), on the high side; the whole stated range lies above it.
By their numbers in this assay, from the lowest: compound 1; then compound 4; then compounds 3 and 2 (each within the scatter of the next).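

Within the data shown here, compound 4 supplies the first step that changes one place only: on an amine nitrogen in a ring, butylsulfonyl in place of isopropylcarbonyl gives in this assay a 45-fold lower number from compound 3 to compound 4 (1.65 log units; beyond the scatter) and counts as a large step. Among these compounds, with the rest of the molecule held the same, this position alone can therefore move the number well beyond the scatter, which the earlier compounds, all differing in more than one place, could not show. Nothing in hand indicates which part of the change accounts for the step.

The change replaces the carbonyl with a sulfonyl and the isopropyl with a butyl chain together, so isopropylsulfonyl or butylcarbonyl on the same nitrogen would be needed to separate the two parts. Also open, from the compounds shown here alone, is whether methylsulfonyl, or a chain carrying an amine or a carboxylic acid, would keep the sulfonyl link while bringing the number in this assay back towards that of compound 3.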